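This account rests on a few compounds, and the source may have more. Where it says the series, first, only, none or still open, it means among the compounds named here.

The two measured compounds share one core and differ in the chain on its aromatic nitrogen. In a functional assay on the whole organism with Rattus norvegicus as the target (on this read-out higher numbers stand for an effect only at larger amounts of compound and lower numbers for an effect already at smaller amounts), compound 1 (`CCN(CC)C(=O)Cn1c(=N)sc2cc(OC(F)(F)F)ccc21`) gives 9 mg/kg. In this assay compound 2 (`CN(C)S(=O)(=O)CCn1c(=N)sc2cc(OC(F)(F)F)ccc21`) gives only a limit, > 10 mg/kg, and not a number.

Compound 3 (`N=c1sc2cc(OC(F)(F)F)ccc2n1CCO`) differs from compound 2 in one place: hydroxy in place of dimethylsulfamoyl on a saturated chain carbon, two bonds along the chain from an aromatic nitrogen. That is hydroxy in place of dimethylsulfamoyl on a saturated chain carbon, two bonds along the chain from an aromatic nitrogen.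

Among the measured compounds shown here, only one measured step bears on this chain: an at least 1.1-fold higher number from compound 1 to compound 2 (0.04 log units; that floor lies within the scatter). It put (dimethylsulfamoyl)methyl in place of diethylcarbamoyl on a saturated chain carbon bound to an aromatic nitrogen. That step stays within the scatter and ends on a limit, and hydroxy played no part in it, so it is a weak guide. The expectation therefore leans on compound 1, with its 9 mg/kg.

The expected step is an at least 1.1-fold lower number from compound 2 to compound 3 (0.04 log units; that floor lies within the scatter), and no change beyond the scatter is expected in either direction. For compound 3 the estimated value is 9 mg/kg, with an expected range from 3 mg/kg to 30 mg/kg.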

Compound 3, dose for half-maximal effect: 8 mg/kg
Compound 3: middle estimate off by 1.1-fold (0.05 log units), on the high side; low and high end bracket the measured number.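

In this assay, exchanging diethylcarbamoyl for the much smaller hydroxymethyl on this chain gives a 1.1-fold lower number from compound 1 to compound 3 (0.05 log units; within the scatter), so the amide end of the chain is not needed for a dose of this size: a group of 1 heavy atom, hydroxy, at the place two bonds along the chain from the aromatic nitrogen does as well as far as this read-out can tell. The change from dimethylsulfamoyl, with its 6 heavy atoms, to hydroxy gives an at least 1.2-fold lower number from compound 2 to compound 3 (0.09 log units; that floor lies within the scatter), and this figure is only a floor, so the true size of the step cannot be read from it. For compound 2 the read-out is a limit and not a number: the limit of > 10 mg/kg in this assay, at which 1 of the 3 values shown sits.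

The compounds shown therefore leave open whether any group on this chain moves the dose beyond the usual scatter, and how far compound 2 really lies from the other two. An amine or a carboxylic acid at the end of the chain, or a longer chain carrying the hydroxy, would test whether this position is truly this forgiving.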